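Pyridin-4-yl in place of pyridin-3-yl: working notes

A few compounds are considered here, and "the series" means these few. Any claim that something is new, unique, unknown or untested is made for them only; others in the source may bear on it.

In a functional assay on ovarian cells (Homo sapiens) for antiproliferative activity (on this read-out lower numbers stand for stronger inhibition of growth and higher numbers for weaker inhibition of growth), compound 1 (`Cc1cn2c(/C=N/NC(=N)N)c(-c3ccncc3)nc2s1`) gives 34700 nM and compound 2 (`N=C(N)N/N=C/c1c(-c2cccnc2)nc2sc(Cl)cn12`) gives 36300 nM. Compound 2 therefore stands level with compound 1, as the two numbers lie within the scatter of each other.

The next compound to be read is compound 3 (`N=C(N)N/N=C/c1c(-c2ccncc2)nc2sc(Cl)cn12`). It has the same atoms as compound 2, joined differently, with pyridin-4-yl in place of pyridin-3-yl on an aromatic carbon.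

Among the measured compounds shown here, no pair of measured compounds differing in one place is available, so the data give no direct reading of this change. Neither direction is favoured, and no step beyond the scatter is expected in this assay. The expected step is a 1.0-fold lower number from compound 2 to compound 3 (0.02 log units; within the scatter). For compound 3 the estimated value is 35000 nM, with an expected range from 20000 nM to 60000 nM.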

Compound 3, concentration for total growth inhibition: 20900 nM
For compound 3 the middle estimate is 1.7-fold (0.22 log units) above the measured one; the range from low to high includes it.
By their numbers in this assay, from the lowest: compounds 3, 1 and 2 (each within the scatter of the next).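

In this assay, among the compounds shown here, the first direct reading of pyridin-4-yl in place of pyridin-3-yl on this aromatic carbon, next to the ring nitrogen, is a 1.7-fold lower number from compound 2 to compound 3 (0.24 log units; within the scatter) and so the two groups are not told apart at this position. With pyridin-4-yl held constant, chloro in place of methyl at the other aromatic carbon gives a 1.7-fold lower number from compound 1 to compound 3 (0.22 log units; within the scatter) and this change also stays within the scatter. No measured evidence bears on either step.

Open, on these data alone, is whether a phenyl ring or a pyridin-2-yl group on the same aromatic carbon would give a step beyond the scatter. Also open, as far as these compounds go, is whether an amine, a carboxylic acid or a longer chain in place of chloro or methyl would separate from these compounds.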